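This account rests on a few compounds, and the source may have more. Where it says the series, first, only, none or still open, it means among the compounds named here.

compound 1 `CCCCc1ccc(-c2c(C)[nH]c(=O)n2C)cc1`: 10700 nM
compound 2 `Cc1[nH]c(=O)n(C)c1-c1ccc(OC(C)C)cc1`: 20400 nM
compound 3 `CCCCCOc1ccc(-c2c(C)[nH]c(=O)n2C)cc1`: 4500 nM

These values come from a functional assay on brain (Rattus norvegicus, strain Wistar) for inhibition; on this read-out higher numbers stand for weaker inhibition and lower numbers for stronger inhibition. Compound 3 has the lowest number of the three, so it shows the strongest inhibition here. The next structure, compound 4 `Cc1[nH]c(=O)n(C)c1-c1ccc(-c2ccccc2)cc1`, carries phenyl in place of pentyloxy on an aromatic carbon. The nearest evidence comes from swaps at this same carbon, which gave a 2.4-fold lower number from compound 1 to compound 3 (0.38 log units; beyond the scatter) and a 4.5-fold lower number from compound 2 to compound 3 (0.66 log units; beyond the scatter), while a 1.9-fold higher number from compound 1 to compound 2 (0.28 log units; within the scatter) stayed within the scatter. These steps are modest, but none of them introduces a ring at this carbon, so the guide is loose. A modest move toward weaker inhibition seems likely, since compound 3 sits lowest at 4500 nM. The expected change is a 1.8-fold higher number from compound 3 to compound 4 (0.25 log units; within the scatter). For compound 4 the estimated value is 8000 nM, with an expected range of 2500 nM to 25000 nM.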

Compound 4, half-maximal inhibitory concentration: 6300 nM
The estimate for compound 4 lay 1.3-fold (0.10 log units) above the measured number, within the range that was stated.
By their numbers in this assay, from the lowest: compounds 3, 4, 1 and 2 (each within the scatter of the next, the first and the last beyond it).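

In this assay a ring is tolerated at this carbon: phenyl in place of pentyloxy gives a 1.4-fold higher number from compound 3 to compound 4 (0.15 log units; within the scatter) and so cannot be told apart from the chain. Phenyl in place of butyl gives a 1.7-fold lower number from compound 1 to compound 4 (0.23 log units; within the scatter) and likewise stays level, whereas phenyl in place of isopropoxy gives a 3.2-fold lower number from compound 2 to compound 4 (0.51 log units; beyond the scatter) and is the only one of these steps that clearly counts. No measurement shown explains these differences.

On these data alone, whether a ring holding nitrogen, such as pyridyl, or a phenyl carrying a chloro or methoxy group would do the same stays open, as does a longer chain such as heptyloxy.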